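Chain branching at the shared core: compound 2 to compound 4

A few compounds are considered here, and "the series" means these few. Any claim that something is new, unique, unknown or untested is made for them only; others in the source may bear on it.

Working notes on the series. Three members have been measured in an in vitro functional assay on cells for agonist activity at Bombesin receptor subtype-3 (Mus musculus), read by luminescence and calcium flux (a higher number here means that more compound is needed for the effect, a lower number that less compound is needed), so far. Compound 2 `CC(C)(C)Cc1cnc(CCc2ccc(-c3ccccc3C(=O)O)cc2)[nH]1`, which carries a tert-butyl on the saturated chain carbon bound to an aromatic carbon, gives 6.3 nM in this assay, the lowest of the two numbers shown. Compound 1 `CCCCc1cnc(C(CC)Cc2ccc(-c3ccccc3C(=O)O)cc2)[nH]1`, built with a butyl group and a differently shaped linker, gives 340 nM in this assay, a gap beyond the usual scatter. For compound 3 `CCCCc1cnc(Cc2ccc(-c3ccccc3C(=O)O)cc2)[nH]1` this assay reports only a limit, > 10000 nM, which is the limit of > 10000 nM in this assay, at which 1 of the 3 values shown sits.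

Compound 4 `CC(C)CCc1cnc(CCc2ccc(-c3ccccc3C(=O)O)cc2)[nH]1` remains to be measured; it differs from compound 2 in one respect: isobutyl in place of tert-butyl on a saturated chain carbon bound to an aromatic carbon. Among the compounds with values here, no pair differing in a single place has been measured, so the size of this step is open. Since compound 2 holds the low number and the less branched butyl of compound 1 sits far higher, a loss of potency is expected. Compound 4 is therefore estimated at 40 nM, with a range of 10 nM to 200 nM. That estimate means an expected step of a 6.3-fold higher number from compound 2 to compound 4 (0.80 log units; beyond the scatter), a loss beyond the scatter but well short of the limit.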

Compound 4, half-maximal effective concentration: 10 nM
The estimate for compound 4 lay 4.0-fold (0.60 log units) above the measured number; low and high end bracket the measured number.
By their numbers in this assay, from the lowest: compounds 2 and 4 (each within the scatter of the next); then compound 1. At a limit, above all of these: compound 3.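

Within the data shown here, replacing tert-butyl with isobutyl on a saturated chain carbon bound to an aromatic carbon gives the first step that differs in a single place, and in this assay it reads a 1.6-fold higher number from compound 2 to compound 4 (0.20 log units; within the scatter). At this place on the shared core, the two groups, which have the same atoms joined differently, therefore cannot be told apart in this assay, so the quaternary carbon of tert-butyl is not required to keep the number in this range. Nothing given here bears on a cause for this step.

Still open, going by these compounds, is how a longer chain such as hexyl, or an amine on the chain, would read on this core. Compound 1 and compound 3 carry butyl with a different linker, so the contribution of the chain on its own remains unseparated from that of the linker.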